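Trimming the tert-butyl group on a weak inhibitor

This account rests on a few compounds, and the source may have more. Where it says the series, first, only, none or still open, it means among the compounds named here.

Compound 1 `CCC(C)(C)/N=C(\NC#N)Nc1ccc(I)cc1`: 1.4 nM
Compound 2 `CC(C)(C)/N=C(\NC#N)Nc1ccc(C#N)cc1`: 530 nM

Both compounds were tested in a functional assay (aorta) for inhibition, with Rattus norvegicus as the target; a higher number here means a weaker inhibitor, a lower number a stronger inhibitor. Compound 2 has the higher number of the two, which makes it the weaker inhibitor, and its gap to compound 1 lies well beyond the scatter. The two differ in more than one place, so that gap cannot be credited to any single change.

Compound 3 `CC(C)/N=C(\NC#N)Nc1ccc(C#N)cc1` is compound 2 altered in one place: hydrogen in place of methyl on a saturated chain carbon bound to a double-bonded nitrogen and two saturated chain carbons. This turns tert-butyl to isopropyl. Among the measured compounds shown here, no measured pair shows this change, so the expectation is a judgement: a modest move towards a higher number in this assay, with a result inside the scatter still possible. The step expected is a 2.5-fold higher number from compound 2 to compound 3 (0.39 log units; beyond the scatter). For compound 3 the estimated value is 1300 nM, with an expected range from 350 nM to 5000 nM.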

Compound 3, half-maximal inhibitory concentration: 19000 nM
Compound 3: middle estimate off by 15-fold (1.16 log units), on the low side; measured number outside the range, above it.
By their numbers in this assay, from the lowest: compound 1; then compound 2; then compound 3.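

Turning tert-butyl to isopropyl gives a 36-fold higher number from compound 2 to compound 3 (1.55 log units; beyond the scatter) in this assay. Among the compounds shown here, this is the first comparison here that isolates a single change, and it shows that this position is far from indifferent: one methyl on the saturated chain carbon bound to a double-bonded nitrogen separates a weak inhibitor from a much weaker one. Nothing available here accounts for the size of this loss.

The compounds shown leave open whether a larger group in this place, such as cyclohexyl or adamantyl, would give a lower number than tert-butyl, or whether a ring of similar size, such as cyclobutyl, could stand in for it. They also leave open whether the same trim would cost as much in compound 1, which carries iodine instead of the nitrile.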